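From 4-chlorophenyl to 2,4-dichlorophenyl

A few compounds are considered here, and "the series" means these few. Any claim that something is new, unique, unknown or untested is made for them only; others in the source may bear on it.

Values in an ADME assay on L02 cells (Homo sapiens) for cytotoxicity, read by MTT assay, with a stated time of 24 h; a lower number here means a stronger inhibitor, a higher number a weaker inhibitor:
Compound 1 `COc1cc(/C=C2\CN(C)C/C(=C\c3ccccc3F)C2=O)cc(OC)c1OC` gives 12100 nM
Compound 2 `COc1cc(/C=C2\CN(C)C/C(=C\c3ccc(Cl)cc3Cl)C2=O)cc(OC)c1` gives 18800 nM
Compound 3 `COc1cc(/C=C2\CN(C)C/C(=C\c3ccc(Cl)cc3)C2=O)cc(OC)c1OC` gives 14000 nM

Compound 3 lies within the scatter of both compound 1 and compound 2, so the three values set no order. Compound 4 `COc1cc(/C=C2\CN(C)C/C(=C\c3ccc(Cl)cc3Cl)C2=O)cc(OC)c1OC` differs from compound 3 by chloro in place of hydrogen on an aromatic carbon, ortho to a large group and meta to a chloro group (chloro in place of hydrogen on an aromatic carbon). Among the compounds with values here, the one measured step bearing on this, a 1.2-fold higher number from compound 1 to compound 3 (0.06 log units; within the scatter), alters the same aryl group and stays within the scatter. No step beyond the scatter is therefore expected, and the expected change is a 1.1-fold higher number from compound 3 to compound 4 (0.06 log units; within the scatter). For compound 4 the estimated value is 16000 nM, with an expected range from 8500 nM to 30000 nM.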

Compound 4, half-maximal inhibitory concentration: 13400 nM
For compound 4 the middle estimate is 1.2-fold (0.08 log units) above the measured one; the measured number falls inside the stated range.
By their numbers in this assay, from the lowest: compounds 1, 4, 3 and 2 (each within the scatter of the next).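

In this assay chloro in place of hydrogen on an aromatic carbon, ortho to a large group and meta to a chloro group, stays within the scatter (a 1.0-fold lower number from compound 3 to compound 4 (0.02 log units; within the scatter)). The addition of a methoxy group (a 1.4-fold lower number from compound 2 to compound 4 (0.15 log units; within the scatter)) and 2,4-dichlorophenyl in place of 2-fluorophenyl (a 1.1-fold higher number from compound 1 to compound 4 (0.04 log units; within the scatter)) also stay within it. All three new steps therefore leave the four compounds without an order in this assay.

The compounds shown leave open whether an amine or a carboxylic acid at this position would give a step beyond the scatter. No measured evidence accompanies these values to account for them.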